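The source may hold more compounds than are shown below. What is called first, only, known or untested is meant among the compounds shown, and "the series" means these compounds.

Measured compounds in a functional assay on the whole organism with Rattus norvegicus as the target, at a dose of 100 mg/kg; on this read-out higher numbers stand for more inhibition at the one dose given (going by the name of the read-out) and lower numbers for less inhibition:
- compound 1 `CC/N=C(/NC#N)NCCCCn1nc(-c2ccccc2)ccc1=O`: 58.8%
- compound 2 `CC/N=C(/NC#N)NCCCCn1nc(-c2ccccc2)c(C)cc1=O`: 38.8%
- compound 3 `CC/N=C(/NC#N)NCCCCn1nc(-c2ccccc2)cc(C)c1=O`: 42.5%

Compound 1 stands highest of the three numbers in this assay; compound 3 comes nearest, compound 2 furthest, and both steps away from compound 1 are beyond the scatter.

The two measured steps both put a methyl in place of a hydrogen on an aromatic carbon of the shared core: a number 20 percentage points lower from compound 1 to compound 2 (beyond the scatter) and a number 16.3 percentage points lower from compound 1 to compound 3 (beyond the scatter), each a modest loss.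

Compound 4 `C/N=C(\NC#N)NCCCCn1nc(-c2ccccc2)ccc1=O` is not yet measured. It differs from compound 1 on the other side of the molecule: a group of 6 heavy atoms (3 carbon, 3 nitrogen; no ring) in place of a group of 7 heavy atoms (4 carbon, 3 nitrogen; no ring), on an amine nitrogen. Among the measured compounds shown here, neither measured step touches this amine nitrogen or the chain attached to it, so no step in the set bears directly on the change. The series shows only that small added carbons on the core cost some inhibition; the change to compound 4 removes a carbon instead, at a different place. With nothing to anchor a direction, the expectation is a step of no more than the scatter, a number 3.8 percentage points lower from compound 1 to compound 4 (within the scatter), in either direction. Compound 4 is therefore estimated at 55%, within a range of 35% to 75% in this assay.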

Compound 4, a percentage reported as inhibition, in the whole organism at one dose (the size of the read-out at that dose, not a potency): 79%
Compound 4: middle estimate off by 24 percentage points, on the low side; measured number outside the range, above it.
By their numbers in this assay, from the lowest: compounds 2 and 3 (each within the scatter of the next); then compound 1; then compound 4.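

In this assay, among the compounds shown here, the amine nitrogen turns out to be a place where the read-out responds: a group of 6 heavy atoms (3 carbon, 3 nitrogen; no ring) in place of a group of 7 heavy atoms (4 carbon, 3 nitrogen; no ring) gives a number 20.2 percentage points higher from compound 1 to compound 4 (beyond the scatter) and is the only step in the set that raises the number. The earlier steps shown here touched only the shared core, so they said nothing about this side of the molecule, and here the counted donors and acceptors are the same in both groups. Nothing measured accounts for the step.

From the compounds shown here alone, it remains open whether a bare hydrogen, a propyl group or a longer chain on this amine nitrogen would continue the trend. Also open, going by these compounds, is whether a methyl on the core costs as much in compound 4 as in compound 1.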